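The compounds below may be only part of what the source reports. "The series", "measured", "known", "first", "only" and "open" are said of these compounds alone.

Measured compounds:
compound 1 `Cc1c(C)c2c(c(C)c1O)CCC(C)(COc1ccc(/C=C3\SC(=O)NC3=O)cc1)O2`, 3120 ng.h/mL;
compound 2 `Cc1c(C)c2c(c(C)c1OCc1ccccc1)CCC(C)(COc1ccc(/C=C3\SC(=O)NC3=O)cc1)O2`, 18500 ng.h/mL;
compound 3 `Cc1c(C)c2c(c(C)c1OCc1ccccc1)CCC(C)(CN1CCC[C@H]1COc1ccc(/C=C3\SC(=O)N(C(=O)CC(O)C(=O)O)C3=O)cc1)O2`, 51700 ng.h/mL.

In an ADME assay on the whole organism for pharmacokinetics, with Rattus norvegicus as the target, at a dose of 100 mg/kg by the oral route (a lower number here means less compound in the circulation, a higher number more compound in the circulation at the dose given), compound 2 gives 18500 ng.h/mL, the second highest of the three numbers: compound 3 gives 51700 ng.h/mL and compound 1 gives 3120 ng.h/mL. Compound 4 `Cc1c(C)c2c(c(C)c1OCc1ccccc1)CCC(C)(COc1ccc(CC3SC(=O)NC3=O)cc1)O2` differs from compound 2 by a group of 8 heavy atoms (4 carbon, 1 nitrogen, 2 oxygen, 1 sulfur; one five-membered non-aromatic ring with 2 hetero atoms) in place of a group of 8 heavy atoms (4 carbon, 1 nitrogen, 2 oxygen, 1 sulfur; one five-membered non-aromatic ring with 2 hetero atoms), on an aromatic carbon. For the measured compounds named here, no measured step covers this change. Going by the values given here, the one measured step, a 5.9-fold higher number from compound 1 to compound 2 (0.77 log units; beyond the scatter), concerns a different change, and compound 3 differs from compound 2 in several places at once. With nothing bearing on the change itself, compound 4 is expected to sit close to compound 2, with a step of a 1.0-fold lower number from compound 2 to compound 4 (0.01 log units; within the scatter), which lies within the scatter. Compound 4 is therefore estimated at 18000 ng.h/mL, with a range from 6000 ng.h/mL to 50000 ng.h/mL.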

Compound 4, area under the concentration-time curve: 29800 ng.h/mL
Compound 4: the middle estimate sits 1.7-fold (0.22 log units) below what was measured, and the stated range covers the measured number.
By their numbers in this assay, from the lowest: compound 1; then compounds 2, 4 and 3 (each within the scatter of the next, the first and the last beyond it).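

At this place, on an aromatic carbon para to a large group, the (2,4-dioxo-1,3-thiazolidin-5-yl)methyl group takes the place of a group with one more double bond outside aromatic rings, and this assay gives a 1.6-fold higher number from compound 2 to compound 4 (0.21 log units; within the scatter). This exposure therefore does not separate compound 2 from compound 4, so the change leaves the read-out within the usual scatter. No measurement shown bears on this result.

Open, as far as these compounds go, is whether a carboxylic acid or an amine at this place would do the same. Also open, from the compounds shown here alone, is whether this change would behave alike on compound 1 or compound 3.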